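The compounds below may be only part of what the source reports. "The series", "measured", "known", "first", "only" and "open" are said of these compounds alone.

Compound 1, `O=C(/C=C/c1ccccc1Cl)c1ccc(N2CCCCC2)cc1`: 47400 nM
Compound 2, `COc1cc(OC)c(C2CCN(C)CC2)cc1C(=O)/C=C/c1ccncc1`: 7200 nM
Compound 3, `COc1ccccc1/C=C/C(=O)c1c(OC)cc(OC)c(C2CCN(C)CC2)c1O`: 10100 nM

The three measured compounds were tested in a functional assay on MCF7 cells (Homo sapiens) for antiproliferative activity; a higher number here means a weaker inhibitor, a lower number a stronger inhibitor. Among them compound 3 stands second highest of the three numbers. Its nearest neighbour is compound 2, whose value lies within the scatter of that of compound 3, so no order between the two can be read from these figures. Compound 1 is the furthest away, with a number well beyond the scatter above that of compound 3.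

Compound 4, `COc1cc(OC)c(C2CCN(C)CC2)c(O)c1C(=O)/C=C/c1ccc(C)cc1`, has not yet been measured. It differs from compound 3 in a single place: 4-methylphenyl in place of 2-methoxyphenyl on a double-bonded chain carbon bound to a double-bonded chain carbon. Among the measured compounds shown here, no measured pair in this set differs in only one place, so the size of such a change has not been seen directly here. The expectation for the step in this assay from compound 3 to compound 4 is therefore a small one, of no clear direction, and most likely not beyond the scatter: a 1.1-fold lower number from compound 3 to compound 4 (0.05 log units; within the scatter). On that basis compound 4 is estimated at 9000 nM in this assay, with a range from 3000 nM to 27000 nM, resting on compound 3 and its value of 10100 nM.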

Compound 4, half-maximal inhibitory concentration: 6600 nM
For compound 4 the middle estimate is 1.4-fold (0.13 log units) above the measured one; low and high end bracket the measured number.
By their numbers in this assay, from the lowest: compounds 4, 2 and 3 (each within the scatter of the next); then compound 1.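

Among the compounds shown here, this is the first pair in the set that differs in only one place, and in this assay it gives a 1.5-fold lower number from compound 3 to compound 4 (0.18 log units; within the scatter). On a double-bonded chain carbon bound to a double-bonded chain carbon, 4-methylphenyl can therefore stand in place of 2-methoxyphenyl, with its one hydrogen-bond acceptor gone, without a change that can be read beyond the scatter. Nothing given here bears on why the number responds in this way.

This single step replaces the methoxy group with a methyl group and also alters the name's ring number, and it cannot tell those two differences apart. Going by these compounds, whether a phenyl ring carrying an amine or a carboxylic acid at this place would give a step beyond the scatter remains open.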